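Adding a Second Chloro Group to Compound 1

The source may hold more compounds than are shown below. What is called first, only, known or untested is meant among the compounds shown, and "the series" means these compounds.

Compound 1 `Clc1ccc(NC2=NCCC3(CCCCC3)S2)cc1` stands highest of the three measured compounds in a physicochemical assay for lipophilicity, measured as octanol-water partition, at pH 7.4 (a lower number here means a more polar compound, a higher number a more lipophilic compound), where compound 1 gives 2.5. In this assay compound 2 `CC(=O)c1ccc(NC2=NCCC3(CCCCC3)S2)cc1` gives 1.97 and compound 3 `Nc1ccc(NC2=NCCC3(CCCCC3)S2)cc1` gives 1.88. The step of a number 0.53 log units lower from compound 1 to compound 2 (beyond the scatter) and the step of a number 0.62 log units lower from compound 1 to compound 3 (beyond the scatter) both lie beyond the scatter, while the step of a number 0.09 log units lower from compound 2 to compound 3 (within the scatter) lies within it. Compound 4 `Clc1ccc(NC2=NCCC3(CCCCC3)S2)cc1Cl` differs from compound 1 by chloro in place of hydrogen on an aromatic carbon. Within the data shown here, none of the measured steps exchanges hydrogen for chloro; each of them replaces chloro with acetyl or amino, so no measured step bears directly on this change. The expected step is nonetheless a number 0.60 log units higher from compound 1 to compound 4 (beyond the scatter), an increase beyond the scatter. The estimate for compound 4 is 3.1, with a range from 2.7 to 3.5.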

Compound 4, distribution coefficient: 2.45
Compound 4: the middle estimate sits 0.65 log units above what was measured, outside the stated range (below it).
By their numbers in this assay, from the lowest: compounds 3 and 2 (each within the scatter of the next); then compounds 4 and 1 (each within the scatter of the next).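

In this assay, chloro in place of hydrogen on an aromatic carbon, ortho to a chloro group and meta to a large group, gives a number 0.05 log units lower from compound 1 to compound 4 (within the scatter), so this added chloro group leaves compound 4 level with compound 1. The earlier steps shown here only exchanged the existing chloro group, whereas this one shows a change at an aromatic carbon that carries hydrogen in compound 1. Nothing available explains this result.

On these data alone, whether fluoro, methyl or a carboxylic acid at this same place would also leave this assay level with compound 1 remains open.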